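A Shorter Diol Side Chain Replaces the Bromoalkyl Ether

The compounds below may be only part of what the source reports. "The series", "measured", "known", "first", "only" and "open" are said of these compounds alone.

Of the compounds shown here, three have so far been measured in a functional assay on mitochondria (Cricetulus griseus) for inhibition of Monoamine oxidase (Homo sapiens), tested at 3 uM; a higher number here means a stronger effect of the compound at the concentration tested, a lower number a weaker effect. Compound 1 `O=c1c(-c2ccc(O)cc2)coc2cc(CC3OC(CO)C(O)C(O)C3O)ccc12` gives 0%. Compound 2 `O=c1c(-c2ccc(O)cc2)coc2cc(OCCCCCCBr)ccc12` gives 88.5%, and compound 3 `O=C(O)CCCCCCCCCOc1ccc2c(=O)c(-c3ccc(O)cc3)coc2c1` gives 89.6%. On these numbers compound 2 stands second highest of three: its nearest neighbour is compound 3, reached by the step of a number 1.1 percentage points higher from compound 2 to compound 3 (within the scatter), which lies within the scatter, while compound 1 sits far below it, beyond the scatter.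

The unmeasured compound 4 `O=c1c(-c2ccc(O)cc2)coc2cc(OCC(O)CO)ccc12` arises from compound 2 by the change (1,2-dihydroxyethyl in place of 5-bromopentyl on a saturated chain carbon bound to an oxygen on an aromatic ring). For the measured compounds named here, only one measured step touches this part of the molecule, a number 1.1 percentage points higher from compound 2 to compound 3 (within the scatter), and it exchanges the group on a saturated chain carbon six bonds along the chain from the aromatic oxygen while keeping the chain itself; it moves nothing beyond the scatter. The change to compound 4 is of another kind, since the 5-bromopentyl leaves and the much shorter 1,2-dihydroxyethyl enters. Going by the values given here, no measured step exchanges a long chain for a short one. Among the compounds with values here, compound 1, which gives 0%, is the only measured compound with a short side group, and no step to it is defined. Compound 4 is therefore expected to drop by a number 53.5 percentage points lower from compound 2 to compound 4 (beyond the scatter) to an estimated 35%, in the range 5% to 70%.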

Compound 4, a percentage reported as inhibition, at one concentration (the size of the read-out at that concentration, not a potency): 85%
The estimate for compound 4 lay 50 percentage points below the measured number; the measured number lies above the stated range.
By their numbers in this assay, from the lowest: compound 1; then compounds 4, 2 and 3 (each within the scatter of the next).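

In this assay, the step of a number 3.5 percentage points lower from compound 2 to compound 4 (within the scatter) shows that this position, on a saturated chain carbon bound to an oxygen on an aromatic ring, tolerates a much larger exchange than the earlier step showed: 5-bromopentyl, with 6 heavy atoms and no hydrogen-bond donors, gives way to 1,2-dihydroxyethyl, with 4 heavy atoms and 2 hydrogen-bond donors, and the read-out stays within the scatter. Among these compounds, then, neither the long chain nor the bromine is needed for a high read-out at the concentration tested, and a short side group on the aromatic oxygen is compatible with one, while compound 1, at 0%, differs from compound 4 in more than one place and cannot be read against it as a step. Nothing measured alongside these numbers explains why the exchange leaves the read-out in place.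

As far as these compounds go, a read-out at one concentration is not a potency, so any difference in potency between compound 2 and compound 4 remains open. Also open, from the compounds shown here alone, is whether a short chain carrying an amine or a carboxylic acid in place of the two hydroxyl groups would hold the read-out as well.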